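Fluoropyridinyl for Fluorophenyl: Cytotoxicity Expectation for Compound 4

A few compounds are considered here, and "the series" means these few. Any claim that something is new, unique, unknown or untested is made for them only; others in the source may bear on it.

Of the compounds shown here, three have so far been measured in an ADME assay on MRC5 cells (Homo sapiens) for cytotoxicity, read by resazurin assay, with a stated time of 72 h; a higher number here means a weaker inhibitor, a lower number a stronger inhibitor. Compound 1 `CC1(COc2cccc(-c3ccc(F)nc3)n2)CCn2cc([N+](=O)[O-])nc2O1` returns only a limit of the assay, > 64000 nM. Compound 2 `CC1(COc2cccc(-c3ccc(F)cc3)n2)CCn2cc([N+](=O)[O-])nc2O1` likewise returns only a limit, > 64000 nM. Within the data shown here, compound 3 `O=[N+]([O-])c1cn2c(n1)OC(COc1cccc(-c3ccc(F)cc3)n1)CC2` gives the sole actual number, 59000 nM, and therefore stands as the one compound with a readable value in this set; because the other two sit at the limit of > 64000 nM in this assay, at which 2 of the 3 values shown sit, no ordering among the three can be claimed.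

Compound 4 `O=[N+]([O-])c1cn2c(n1)OC(COc1cccc(-c3ccc(F)nc3)n1)CC2` differs from compound 3 by 6-fluoropyridin-3-yl in place of 4-fluorophenyl on an aromatic carbon. The same exchange, taken in the opposite direction, separates compound 1 from compound 2, where a step that the two limits leave unreadable from compound 1 to compound 2. The other measured step, an at least 1.0-fold lower number from compound 2 to compound 3 (0.03 log units; that floor lies within the scatter), concerns the methyl group and does not bear on this exchange. Among the measured compounds shown here, with the only relevant comparison unreadable, no step beyond the scatter is expected in this assay. Compound 4 is therefore expected to give about 64000 nM, with a range from 40000 nM to 100000 nM. The expected step, a 1.1-fold higher number from compound 3 to compound 4 (0.04 log units; within the scatter), is estimated to lie within the scatter, and a limit rather than a number may well be reported.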

Compound 4, half-maximal inhibitory concentration: 35000 nM
Compound 4: the middle estimate sits 1.8-fold (0.26 log units) above what was measured; measured number outside the range, below it.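

In this assay, among these compounds, the exchange of 4-fluorophenyl for 6-fluoropyridin-3-yl, on an aromatic carbon next to the ring nitrogen, now has a readable size for the first time: a 1.7-fold lower number from compound 3 to compound 4 (0.23 log units; within the scatter). The exchange of methyl for hydrogen on the saturated ring carbon can also now be followed with 6-fluoropyridin-3-yl in place, as an at least 1.8-fold lower number from compound 1 to compound 4 (0.26 log units; that floor lies within the scatter). That gives the change a second core to be compared with the first: the same change on two cores in this assay, an at least 1.0-fold lower number (0.03 log units; that floor lies within the scatter) from compound 2 to compound 3 and an at least 1.8-fold lower number (0.26 log units; that floor lies within the scatter) from compound 1 to compound 4; the limit leaves it open whether they differ.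

With the methyl group present, the step between the two aryl groups still cannot be read: the limit of > 64000 nM in this assay, at which 2 of the 4 values shown sit. The compounds shown also leave open whether an amine or a carboxylic acid in place of the fluorine on this ring would carry the number beyond the scatter.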